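The compounds below may be only part of what the source reports. "The series", "measured", "known", "first", "only" and "open" are said of these compounds alone.

Working notes on the series. Compound 1 `O=C1COc2ccc(-c3cnc(Cl)c(NS(=O)(=O)c4ccc(F)cc4)c3)cc2N1c1ccccc1` gives 10300 nM in a functional assay on HeLa cells (Homo sapiens) for antiproliferative activity, read by MTT assay, with a stated time of 72 h; a higher number here means a weaker inhibitor, a lower number a stronger inhibitor. Compound 2 `O=C1COc2ccc(-c3cnc(Cl)c(NS(=O)(=O)c4ccc(F)cc4)c3)cc2N1c1ccc(F)cc1` returns only a limit in this assay, > 40000 nM. Compound 3 `COc1ncc(-c2ccc3c(c2)N(c2ccc(F)cc2)C(=O)CO3)cc1NS(=O)(=O)c1ccc(F)cc1` gives 10500 nM. Compound 2 thus stands at the limit of > 40000 nM in this assay, at which 1 of the 3 values shown sits, the weakest point among the numbers shown, with no number of its own. Going by the values given here, two measured steps touch it: an at least 3.8-fold higher number from compound 1 to compound 2 (0.58 log units; beyond the scatter) and an at least 3.8-fold lower number from compound 2 to compound 3 (0.58 log units; beyond the scatter). Compound 4 `CC(C)N1C(=O)COc2ccc(-c3cnc(Cl)c(NS(=O)(=O)c4ccc(F)cc4)c3)cc21` is not yet measured. isopropyl in place of 4-fluorophenyl on an amide-type nitrogen in a ring The measured pairs change only the fluoro on the ring that sits on the amide-type nitrogen, or the methoxy for chloro elsewhere; an isopropyl on that nitrogen lies outside what they cover. Because compound 2 sits at the limit of > 40000 nM in this assay, at which 1 of the 3 values shown sits, any number for compound 4 can only be placed relative to that limit. Among the compounds with values here, the expected step is an at least 2.0-fold lower number from compound 2 to compound 4 (0.30 log units; that floor lies within the scatter), back toward the number of compound 1, though no measured pair supports it directly. Compound 4 is expected at 20000 nM, within 5000 nM to 60000 nM.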

Compound 4, half-maximal inhibitory concentration: 5380 nM
The estimate for compound 4 lay 3.7-fold (0.57 log units) above the measured number; low and high end bracket the measured number.
By their numbers in this assay, from the lowest: compounds 4, 1 and 3 (each within the scatter of the next). At a limit, above all of these: compound 2.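

In this assay, going by these compounds alone, the earlier compounds changed only a fluoro on the ring at the amide-type nitrogen; here that ring itself goes, and isopropyl in place of 4-fluorophenyl gives an at least 7.4-fold lower number from compound 2 to compound 4 (0.87 log units; beyond the scatter). That step is a floor, as the value for compound 2 is a limit: the limit of > 40000 nM in this assay, at which 1 of the 4 values shown sits. Against the unsubstituted phenyl, isopropyl gives a 1.9-fold lower number from compound 1 to compound 4 (0.28 log units; within the scatter), so this nitrogen carries a group with no ring and the values of the two compounds cannot be told apart.

On these data alone, whether methyl, cyclopropyl or a longer chain ending in an amine on this nitrogen would shift the number beyond the scatter stays open. Also open, as far as these compounds go, is how isopropyl on this nitrogen behaves with methoxy in place of chloro, the change carried by compound 3.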